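Aryl group on the shared core: from compound 3 to compound 4

The compounds below may be only part of what the source reports. "The series", "measured", "known", "first", "only" and "open" are said of these compounds alone.

Compound 1 `COc1ccc(S(=O)(=O)N2CCc3cccc(-c4ccc(C#N)cc4)c32)cc1` gives 17.2 nM in a functional assay on MKN-45 cells (Homo sapiens) for inhibition, with a stated time of 72 h; a lower number here means a stronger inhibitor, a higher number a weaker inhibitor; compound 2 `COc1ccc(S(=O)(=O)N2CCc3cccc(-c4ccc(F)nc4)c32)cc1` gives 145 nM and compound 3 `COc1ccc(S(=O)(=O)N2CCc3cccc(-c4cccs4)c32)cc1` gives 165 nM, the highest of the three numbers. The step of a 1.1-fold higher number from compound 2 to compound 3 (0.06 log units; within the scatter) lies within the scatter, whereas the step of a 9.6-fold higher number from compound 1 to compound 3 (0.98 log units; beyond the scatter) lies beyond it. Compound 4 `COc1ccc(S(=O)(=O)N2CCc3cccc(-c4cccc(F)c4)c32)cc1` carries 3-fluorophenyl in place of thiophen-2-yl on an aromatic carbon. The step of a 9.6-fold higher number from compound 1 to compound 3 (0.98 log units; beyond the scatter) bears on this most directly: the entering group is again a six-membered aromatic ring of carbon only, though with fluorine rather than a nitrile. The step of an 8.4-fold higher number from compound 1 to compound 2 (0.93 log units; beyond the scatter) bears on it less. A move back toward compound 1 is expected, but not the full way. Compound 4 is estimated at 50 nM, range 15 nM to 160 nM. The expected step is a 3.3-fold lower number from compound 3 to compound 4 (0.52 log units; beyond the scatter), a lower number beyond the scatter.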

Compound 4, half-maximal inhibitory concentration: 84.7 nM
Compound 4: middle estimate off by 1.7-fold (0.23 log units), on the low side; the range from low to high includes it.
By their numbers in this assay, from the lowest: compound 1; then compounds 4, 2 and 3 (each within the scatter of the next).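

In this assay, 3-fluorophenyl does not separate from the other two groups: a 1.9-fold lower number from compound 3 to compound 4 (0.29 log units; within the scatter) and a 1.7-fold lower number from compound 2 to compound 4 (0.23 log units; within the scatter) both stay within the scatter. Only 4-cyanophenyl stands apart, with a 4.9-fold higher number from compound 1 to compound 4 (0.69 log units; beyond the scatter), so a six-membered aromatic ring of carbon only does not by itself match compound 1. No evidence on hand accounts for this gap. As far as these compounds go, whether the nitrile itself carries the gap remains open; a phenyl ring bearing an amine or a carboxylic acid in its place would test that.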